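Swapping the Ring on the Carbonyl Carbon

A few compounds are considered here, and "the series" means these few. Any claim that something is new, unique, unknown or untested is made for them only; others in the source may bear on it.

Compound 3 `COc1ccc(C(=O)/C=C/c2cc(-c3cc(OC)c(OC)c(OC)c3)n[nH]2)cc1OC` gives -88% in a functional assay on SF-268 cells (Homo sapiens) for cytotoxicity, read by sulforhodamine B assay, with a stated time of 48 h, tested at 100 uM (a lower number here means a stronger effect, a higher number a weaker effect of the compound at the concentration tested), the lowest number and so the strongest effect of the three measured compounds. Compound 1 `COc1cc(-c2cc(/C=C/C(=O)c3ccc(Cl)c(Cl)c3)[nH]n2)cc(OC)c1OC` gives -15%, and compound 2 `COc1ccc(C(=O)/C=C/c2cc(-c3cc(OC)c(OC)c(OC)c3)n[nH]2)cc1` gives -37%. Compound 4 `COc1cc(-c2cc(/C=C/C(=O)c3ccc(F)c(F)c3)[nH]n2)cc(OC)c1OC` differs from compound 3 in one place: 3,4-difluorophenyl in place of 3,4-dimethoxyphenyl on a carbonyl carbon. The step that bears most on this runs the opposite way: a number 73 percentage points lower from compound 1 to compound 3 (beyond the scatter), where two chlorines gave way to two methoxy groups. The smaller steps of a number 22 percentage points lower from compound 1 to compound 2 (beyond the scatter) and a number 51 percentage points lower from compound 2 to compound 3 (beyond the scatter) point the same way. Because compound 1 gives -15% with two halogens on that ring, compound 4 is expected to lose most of the effect, a rise of a number 68 percentage points higher from compound 3 to compound 4 (beyond the scatter). Compound 4 is therefore estimated at -20%, within -45% to 5%.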

Compound 4, a percentage reported as activity, at one concentration (the size of the read-out at that concentration, not a potency): 1%
Compound 4: middle estimate off by 21 percentage points, on the low side; the measured number falls inside the stated range.
By their numbers in this assay, from the lowest: compound 3; then compound 2; then compound 1; then compound 4.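

Two fluorines on the ring at the carbonyl carbon lose the effect as two chlorines did, with a number 89 percentage points higher from compound 3 to compound 4 (beyond the scatter) and a number 38 percentage points higher from compound 2 to compound 4 (beyond the scatter) and even a number 16 percentage points higher from compound 1 to compound 4 (beyond the scatter) in this assay, so the choice of halogen matters too. Among these four compounds, both methoxy-bearing rings give lower numbers than both halogen-bearing rings, with no exception, and compound 4 is the weakest. Nothing measured here explains this difference. Still open, on these data alone, is whether the loss follows from the halogens themselves or from the absence of methoxy groups. As far as these compounds go, how an amine or a carboxylic acid on this ring would read also remains unknown.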